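The source may report more compounds than this note shows. Statements on the series, on what has been measured and on what is new or still open speak of the compounds shown alone.

Within the data shown here, in an ADME assay on WI-38 cells (Homo sapiens) for cytotoxicity, read by MTT assay, with a stated time of 72 h (a lower number here means a stronger inhibitor, a higher number a weaker inhibitor), three compounds built on one shared core have numbers so far. Compound 1 (`O=C(CCc1cccc2c1B(O)OC2)Nc1cccc(-c2ccc(F)cc2)c1`) gives 4100 nM, compound 2 (`O=C(CCc1cccc2c1B(O)OC2)Nc1cccc(-c2ccc(OC(F)(F)F)cc2)c1`) gives 25000 nM and compound 3 (`O=C(CCc1cccc2c1B(O)OC2)Nc1cccc(-c2cccc(C(F)(F)F)c2)c1`) gives 23000 nM. Compound 3 therefore sits level with compound 2, within the usual scatter of repeated measurements, and clearly above compound 1.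

Compound 4 (`N#Cc1ccc(-c2cccc(NC(=O)CCc3cccc4c3B(O)OC4)c2)cc1`) differs from compound 3 in one place, with 4-cyanophenyl in place of 3-(trifluoromethyl)phenyl on an aromatic carbon. Among the measured compounds shown here, no measured compound carries a nitrile, so the evidence is indirect. For the measured compounds named here, two measured steps bear on the change, and both are modest and go upward. One is a 6.1-fold higher number from compound 1 to compound 2 (0.79 log units; beyond the scatter), with trifluoromethoxy in place of fluoro. The other is a 5.6-fold higher number from compound 1 to compound 3 (0.75 log units; beyond the scatter), with 3-(trifluoromethyl)phenyl in place of 4-fluorophenyl. Among these three compounds, the two higher numbers belong to the two that carry a trifluoromethoxy or trifluoromethyl group, and compound 4 has neither. A move part of the way back toward compound 1 at 4100 nM therefore seems likely.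

The expected change in this assay is a modest one toward a lower number, a 2.3-fold lower number from compound 3 to compound 4 (0.36 log units; beyond the scatter). For compound 4 the estimated value is 10000 nM, with an expected range from 3500 nM to 28000 nM.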

Compound 4, half-maximal inhibitory concentration: 12000 nM
For compound 4 the middle estimate is 1.2-fold (0.08 log units) below the measured one; low and high end bracket the measured number.
By their numbers in this assay, from the lowest: compound 1; then compounds 4, 3 and 2 (each within the scatter of the next, the first and the last beyond it).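

In this assay, putting 4-cyanophenyl in place of 3-(trifluoromethyl)phenyl on this aromatic carbon gives a 1.9-fold lower number from compound 3 to compound 4 (0.28 log units; within the scatter), so the assay does not separate these two compounds. The nitrile does separate compound 4 from the other two neighbours, with a 2.1-fold lower number from compound 2 to compound 4 (0.32 log units; beyond the scatter) and a 2.9-fold higher number from compound 1 to compound 4 (0.47 log units; beyond the scatter), which leaves compound 1, with its 4-fluorophenyl, as the lowest of the four and shows that a higher number than that of compound 1 does not require a trifluoromethyl or trifluoromethoxy group, since compound 4 carries neither. Nothing measured here accounts for these differences.

All four compounds vary only in the group on the outer aromatic ring, and in the step from compound 3 to compound 4 both the group and its place on that ring change at once, so the two contributions cannot be pulled apart. Still open, on these data alone, is how the number would respond to an amine or a carboxylic acid on that ring, or to a longer chain in place of the one joining the amide to the shared core.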